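The compounds below may be only part of what the source reports. "The series", "measured", "known", "first", "only" and "open" are said of these compounds alone.

- compound 1 `O=C1CS/C(=N/Nc2nncc3ccccc23)N1c1ccccc1`: 7.9 nM
- compound 2 `O=S(=O)(Nc1ncccn1)c1ccc(Nc2nncc3ccccc23)cc1`: 0.8 nM
- compound 3 `COc1ccc(NC(=S)NNc2nncc3ccccc23)cc1`: 0.8 nM

In a functional assay on SK-OV-3 cells (Homo sapiens) for antiproliferative activity, read by sulforhodamine B assay, with a stated time of 72 h (on this read-out higher numbers stand for weaker inhibition and lower numbers for stronger inhibition), compound 2 at 0.8 nM stands level with compound 3 at 0.8 nM, within the scatter, and these two share the lowest number of the set. Compound 1 at 7.9 nM lies furthest from compound 2, beyond the scatter.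

Compound 4 `NS(=O)(=O)c1ccc(Nc2nncc3ccccc23)cc1` has hydrogen in place of pyrimidin-2-yl on a sulfonamide nitrogen. Going by the values given here, no measured pair shows this change, so the estimate is tentative. The expected step, a 2.5-fold higher number from compound 2 to compound 4 (0.40 log units; beyond the scatter), is a moderate rise in the number, possibly staying within the scatter. For compound 4 the estimated value is 2 nM, with an expected range of 0.4 nM to 10 nM.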

Compound 4, half-maximal inhibitory concentration: 0.8 nM
Compound 4: the middle estimate sits 2.5-fold (0.40 log units) above what was measured; measured number inside the range.
By their numbers in this assay, from the lowest: compounds 2, 3 and 4 (each within the scatter of the next); then compound 1.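

In this assay, going by these compounds alone, hydrogen in place of pyrimidin-2-yl on a sulfonamide nitrogen gives no change at the digits printed from compound 2 to compound 4 (within the scatter) and is the first step read at this position. The pyrimidin-2-yl ring is therefore dispensable for the read-out here, and the plain sulfonamide suffices. Nothing available explains this result.

Still open, on these data alone, is whether larger or different groups on this nitrogen, such as a methyl, an acetyl or a phenyl ring, are tolerated equally. Also open, as far as these compounds go, is whether a carboxylic acid or a simple amide could replace the sulfonamide.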